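Saturated Ring Replaces the Unsaturated Chain on the Amide

This account rests on a few compounds, and the source may have more. Where it says the series, first, only, none or still open, it means among the compounds named here.

Compound 3 `C/C=C/C(=O)Nc1c(C(O)(C(F)(F)F)C(F)(F)F)ccc2ccccc12` is one of three amides built on a shared core. In an assay on LtK cells with ATP-sensitive inward rectifier potassium channel 11 (Homo sapiens) as the target (a higher number here means that more compound is needed for the effect, a lower number that less compound is needed), compound 3 gives 72 nM. Among the measured compounds it holds the middle place: compound 1 `CC(=O)Nc1c(C(O)(C(F)(F)F)C(F)(F)F)ccc2ccccc12` gives 18 nM, and the change from methyl to prop-1-en-1-yl costs a 4.0-fold higher number from compound 1 to compound 3 (0.60 log units; beyond the scatter); compound 2 `CCC(C)C(=O)Nc1c(C(O)(C(F)(F)F)C(F)(F)F)ccc2ccccc12` gives 177000 nM, so that a 2500-fold lower number from compound 2 to compound 3 (3.39 log units; beyond the scatter) separates the two.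

Compound 4 `O=C(Nc1c(C(O)(C(F)(F)F)C(F)(F)F)ccc2ccccc12)C1CCCC1` differs from compound 3 by cyclopentyl in place of prop-1-en-1-yl on a carbonyl carbon. Going by the values given here, two measured steps bear on this change. The replacement of methyl by sec-butyl, a group without a double bond, brought a 9800-fold higher number from compound 1 to compound 2 (3.99 log units; beyond the scatter); the replacement of methyl by the unsaturated prop-1-en-1-yl brought only a 4.0-fold higher number from compound 1 to compound 3 (0.60 log units; beyond the scatter). Cyclopentyl, like sec-butyl, carries no double bond and is attached at the carbonyl carbon through a substituted carbon, so the step to compound 4 is expected to follow the direction of the sec-butyl example, a large rise in the number, though how closely a ring of five carbons tracks an open chain is not settled by these three compounds alone.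

Compound 4 is therefore estimated at 20000 nM in this assay, with a range from 2000 nM to 200000 nM, an expected step of a 280-fold higher number from compound 3 to compound 4 (2.44 log units; beyond the scatter).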

Compound 4, half-maximal effective concentration: 495 nM
Compound 4: middle estimate off by 40-fold (1.61 log units), on the high side, and the stated range ends above it.
By their numbers in this assay, from the lowest: compound 1; then compound 3; then compound 4; then compound 2.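

In this assay the cyclopentyl group does not follow the open sec-butyl chain, even though neither carries a double bond: the ring gives a 360-fold lower number from compound 2 to compound 4 (2.55 log units; beyond the scatter) and so stands far closer to the unsaturated prop-1-en-1-yl chain, with only a 6.9-fold higher number from compound 3 to compound 4 (0.84 log units; beyond the scatter) separating those two. The lack of a double bond in the group on the carbonyl carbon therefore does not by itself bring the very high number of compound 2, and compound 4 shows that a group larger than prop-1-en-1-yl can be accepted here at modest cost. Replacing methyl still has a price, seen in a 28-fold higher number from compound 1 to compound 4 (1.44 log units; beyond the scatter) and leaving compound 1 with the lowest number of the four. No measurement shown here accounts for the wide gap between the ring and the open sec-butyl chain.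

On these data alone, it remains open whether cyclopropyl or cyclohexyl on the carbonyl carbon would stay near compound 4 or move toward compound 2. Equally open, as far as these compounds go, is how a longer straight chain such as n-butyl, or a chain ending in an amine or a carboxylic acid, would fare at this position.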